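Dimethoxychromone series: ether side chains and antiproliferative read-out

The source may hold more compounds than are shown below. What is called first, only, known or untested is meant among the compounds shown, and "the series" means these compounds.

Measured compounds:
compound 1 `COc1cc(OC)c2c(=O)cc(-c3ccc(OC4CCN(C)CC4)cc3)oc2c1` — 28%
compound 2 `COc1cc(OC)c2c(=O)cc(-c3ccc(OCCN4CCCC4=O)cc3)oc2c1` — 7%
compound 3 `COc1cc(OC)c2c(=O)cc(-c3ccc(OC4CCNCC4)cc3)oc2c1` — "not active" (no number reported)

Among the compounds with values here, in a functional assay (Homo sapiens) for antiproliferative activity, read by resazurin assay, with a stated time of 48 h, tested at 5 uM (on this read-out higher numbers stand for a stronger effect at the one concentration tested and lower numbers for a weaker effect), compound 1 gives 28% and compound 2 gives 7%; the one counted step, a number 21 percentage points lower from compound 1 to compound 2 (beyond the scatter), shows that the ether side chain shifts the read-out. Compound 3 gives "not active" (no number reported), with no number at all, so it sits at the weak end of the three.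

Compound 4 `COc1cc(OC)c2c(=O)cc(-c3ccc(OCC(O)CN(C)C)cc3)oc2c1` differs from compound 3 by 3-(dimethylamino)-2-hydroxypropyl in place of piperidin-4-yl on an oxygen on an aromatic ring. Within the data shown here, no measured step covers this change; the single step from compound 1 to compound 2 concerns other groups. The new chain carries a methylated nitrogen, as does compound 1, so a small rise above compound 3 is expected, of uncertain size. For compound 4 the expected value is 15%, within 0% to 35%.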

Compound 4, a percentage reported as inhibition, at one concentration (the size of the read-out at that concentration, not a potency): 42%
The estimate for compound 4 lay 27 percentage points below the measured number, and the stated range ends below it.
By their numbers in this assay, from the lowest: compound 2; then compound 1; then compound 4.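

In this assay, the open 3-(dimethylamino)-2-hydroxypropyl chain on the oxygen on the aromatic ring reads higher than the ring-bearing 1-methylpiperidin-4-yl (a number 14 percentage points higher from compound 1 to compound 4 (beyond the scatter)), so among these compounds a ring at this position is not required for the read-out, and the rise over the 2-(2-oxopyrrolidin-1-yl)ethyl chain is larger (a number 35 percentage points higher from compound 2 to compound 4 (beyond the scatter)). Steps involving compound 3 cannot be read, as it has no number. Nothing available explains these differences.

Going by these compounds, whether the hydroxy group of the chain matters stays open, a question for a plain 3-(dimethylamino)propyl chain. Also open, on these data alone, is whether a morpholine in place of the dimethylamino group would keep the read-out.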